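The source may hold more compounds than are shown below. What is called first, only, known or untested is meant among the compounds shown, and "the series" means these compounds.

Compound 1 `COc1ccc2[nH]cc(/C=C(\C#N)C(=O)c3c[nH]c4ccccc34)c2c1`: 25100 nM
Compound 2 `N#C/C(=C\c1c[nH]c2cc(F)ccc12)C(=O)c1c[nH]c2cc(F)ccc12`: > 50000 nM (a limit)
Compound 3 `COc1ccc2[nH]cc(/C=C(\C#N)C(=O)c3c[nH]c4ccc(OC)cc34)c2c1`: > 50000 nM (a limit)

Going by the values given here, in a functional assay on MIA PaCa-2 cells (Homo sapiens) for cytotoxicity, read by WST assay, with a stated time of 48 h (a lower number here means a stronger inhibitor, a higher number a weaker inhibitor), compound 1 gives 25100 nM, the only actual number in this small set. The other two values are limits. Compound 4 `COc1ccc2[nH]cc(/C=C(\C#N)C(=O)c3c[nH]c4cc(F)ccc34)c2c1` keeps the core of compound 1 and differs from it as follows: fluoro in place of hydrogen on an aromatic carbon. Among the compounds with values here, the one measured step from compound 1 is an at least 1.9-fold higher number from compound 1 to compound 3 (0.29 log units; that floor lies within the scatter), and it comes with methoxy in place of hydrogen on an aromatic carbon. Compound 2, which also carries fluoro, reports only a limit of > 50000 nM. On that basis, a small move towards a higher number is expected in this assay, perhaps none beyond the scatter. The expected step is a 1.4-fold higher number from compound 1 to compound 4 (0.14 log units; within the scatter). For compound 4 the estimated value is 35000 nM, with an expected range from 15000 nM to 50000 nM.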

Compound 4, half-maximal inhibitory concentration: > 50000 nM
Compound 4 gave a limit, no number; the forecaster's own chance of this, stated with the estimate: 45%; at least 1.4-fold (0.15 log units) between middle value and limit.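

In this assay, the step for fluoro in place of hydrogen on this aromatic carbon is an at least 1.9-fold higher number from compound 1 to compound 4 (0.29 log units; that floor lies within the scatter). Compound 4 is known only as a limit, so the true size of this step cannot be read, and its floor shows no change beyond the scatter. The earlier compounds showed such a single step only with methoxy, and now a second single change from compound 1 ends at the same limit: the limit of > 50000 nM in this assay, at which 3 of the 4 values shown sit.

On these data alone, whether an amine or a carboxylic acid on this aromatic carbon would give a number rather than a limit stays open. As far as these compounds go, whether any group here would give a lower number than compound 1 also stays open.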